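A few compounds are considered here, and "the series" means these few. Any claim that something is new, unique, unknown or untested is made for them only; others in the source may bear on it.

Measured compounds, a functional assay on HL-60 cells (Homo sapiens), with a stated time of 2 days; on this read-out lower numbers stand for stronger inhibition and higher numbers for weaker inhibition:
- compound 1, `COc1ccc(CNC(=O)c2[nH]cnc2C(=O)Nc2ccc(Cl)c(Cl)c2)cc1`: 24300 nM
- compound 2, `C[C@@H](NC(=O)c1[nH]cnc1C(=O)Nc1ccc(Cl)c(Cl)c1)C(=O)OC(C)(C)C`: 4600 nM

Within the data shown here, compound 2 holds the lowest of the two numbers in this assay; its nearest neighbour is compound 1, and the single measured step, a 5.3-fold lower number from compound 1 to compound 2 (0.72 log units; beyond the scatter), separates them.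

Compound 3, `COC(=O)[C@H](NC(=O)c1[nH]cnc1C(=O)Nc1ccc(Cl)c(Cl)c1)C(C)C`, differs from compound 2 by 1-(methoxycarbonyl)-2-methylpropyl in place of 1-(tert-butoxycarbonyl)ethyl on an amide-type nitrogen. Among the measured compounds shown here, no measured step covers an exchange of one such ester-bearing chain for another; the step from compound 1 to compound 2 only shows that a chain of this kind does better than the benzylic group in this assay. Compound 3 is therefore expected to stay close to compound 2, with a step of a 1.1-fold higher number from compound 2 to compound 3 (0.04 log units; within the scatter), within the scatter. The estimate for compound 3 is 5000 nM, range 1500 nM to 16000 nM.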

Compound 3, half-maximal inhibitory concentration: 8500 nM
Estimate against measurement, compound 3: 1.7-fold (0.23 log units) below; the measured number falls inside the stated range.
By their numbers in this assay, from the lowest: compounds 2 and 3 (each within the scatter of the next); then compound 1.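

In this assay, 1-(methoxycarbonyl)-2-methylpropyl in place of 1-(tert-butoxycarbonyl)ethyl on the amide-type nitrogen gives no clear difference (a 1.8-fold higher number from compound 2 to compound 3 (0.27 log units; within the scatter)). The advantage over 4-methoxybenzyl is therefore not confined to one ester-bearing chain, as it also holds for the second chain (a 2.9-fold lower number from compound 1 to compound 3 (0.46 log units; beyond the scatter)). Nothing available explains either step.

The ester and the rest of the chain change together between these compounds, so neither contribution can be read alone. Going by these compounds, whether the ester matters at all remains open, a question that a carboxylic acid in its place would address.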